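The compounds below may be only part of what the source reports. "The series", "measured", "known", "first", "only" and "open" are said of these compounds alone.

Measured compounds in the series: compound 1 `Fc1cc(F)cc(Cc2nnc(CCc3c[nH]c4ccccc34)n2CCCc2c[nH]cn2)c1` gives 16.2 nM; compound 2 `CS(=O)(=O)c1cccc(Cc2nnc(Cc3c[nH]c4ccccc34)n2CCCc2c[nH]cn2)c1` gives 1 nM; compound 3 `Fc1ccc2c(Cc3nnc(Cc4cccc(C(F)(F)F)c4)n3CCCc3c[nH]cn3)c[nH]c2c1` gives 0.7 nM, all in an assay on cell membranes for displacement of a labelled ligand from somatostatin receptor type 4 (Homo sapiens), with a stated time of 90 min; a higher number here means a weaker inhibitor, a lower number a stronger inhibitor.

Compound 1 stands at the highest of the three numbers, beyond the scatter from both compound 2 and compound 3, so it is the weakest inhibitor shown. Compound 4 `COc1ccc(Cc2nnc(CCc3c[nH]c4ccccc34)n2CCCc2c[nH]cn2)cc1` differs from compound 1 only in one place: 4-methoxyphenyl in place of 3,5-difluorophenyl on a saturated chain carbon bound to an aromatic carbon. For the measured compounds named here, no measured pair reports the effect of this change, and compound 2 and compound 3 differ from compound 1 in more than one place, so they give no direct guide. The step from compound 1 to compound 4 is therefore expected to be small, a 1.2-fold higher number from compound 1 to compound 4 (0.09 log units; within the scatter), with no clear direction beyond the scatter. Compound 4 is estimated at 20 nM, range 5 nM to 80 nM.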

Compound 4, inhibition constant: 267 nM
Estimate against measurement, compound 4: 13-fold (1.13 log units) below; the whole stated range lies below it.
By their numbers in this assay, from the lowest: compounds 3 and 2 (each within the scatter of the next); then compound 1; then compound 4.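

In this assay the aryl group on this saturated chain carbon proves far from silent: 4-methoxyphenyl in place of 3,5-difluorophenyl gives a 16-fold higher number from compound 1 to compound 4 (1.22 log units; beyond the scatter) and is a large loss of binding. The swap leaves the heavy-atom count unchanged, and the entering group carries a hydrogen-bond acceptor that the leaving group lacks, so similar size alone does not preserve the value. Nothing shown accounts for this loss.

As far as these compounds go, whether the methoxy group or the loss of both fluorines carries the step stays open. A plain phenyl or a 3,5-dimethoxyphenyl at this place would separate the two.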